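The source may hold more compounds than are shown below. What is called first, only, known or untested is meant among the compounds shown, and "the series" means these compounds.

Working notes on the series. The shared core is shown by compound 1, `O=C(NO)c1cn(Cc2ccc(Br)cc2)c2ccccc2c1=O`, for which a functional assay, tested at 50 uM (on this read-out lower numbers stand for a weaker effect and higher numbers for a stronger effect at the one concentration tested), records "not determined" (no result reported). Among the measured compounds shown here, compound 2, `O=C(NO)c1cn(Cc2ccc(O)cc2)c2ccccc2c1=O`, is the only member with a number: in this assay compound 2 gives 51.1%, and this single value is the whole reference, since no step between two measured compounds can be drawn. Compound 3, `O=C(NO)c1cn(Cc2ccc(O)c(O)c2)c2ccccc2c1=O`, is still to be tested. Its difference from compound 2 is hydroxy in place of hydrogen on an aromatic carbon, read one bond further out as 4-hydroxyphenyl to 3,4-dihydroxyphenyl. For the measured compounds named here, nothing among the measured compounds shows how this assay responds to a hydroxy entering on the aromatic ring in place of hydrogen, so no direction can be taken from the data themselves. The step expected from compound 2 to compound 3 is therefore a number 1.1 percentage points lower from compound 2 to compound 3 (within the scatter), that is, none beyond the scatter. For compound 3 the estimate in this assay is 50%, with a range from 30% to 70% that is kept wide because compound 2 with 51.1% is the only anchor available.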

Compound 3, a percentage reported as activity, at one concentration (the size of the read-out at that concentration, not a potency): 65.1%
The estimate for compound 3 lay 15.1 percentage points below the measured number; the measured number falls inside the stated range.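

In this assay the series now has its first readable step, a number 14 percentage points higher from compound 2 to compound 3 (beyond the scatter), for hydroxy in place of hydrogen on an aromatic carbon, ortho to a hydroxy group and meta to a large group. The change from 4-hydroxyphenyl to 3,4-dihydroxyphenyl therefore gives a larger read-out at the one concentration tested, which shows that this ring position is open to substitution in this assay and that the direction of the change here is upward, although this is a single pair and a difference in read-out size rather than in potency. No available measurement bears on the reason for this step.

Whether the step belongs to hydroxy as such stays open, since the compounds shown do not tell how a methoxy, an amine or a carboxylic acid would read at the same ring position, or how a lone hydroxy there would read without the one already on the ring. Any step involving compound 1 cannot be read, so the comparison between bromine and hydroxy on the ring also remains unresolved.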